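Isopropyl to allyl on a small ether series

This account rests on a few compounds, and the source may have more. Where it says the series, first, only, none or still open, it means among the compounds named here.

In a functional assay on HL-60 cells (Homo sapiens) for inhibition, read by MTT assay, with a stated time of 72 h (a lower number here means a stronger inhibitor, a higher number a weaker inhibitor), compound 3 `CC(C)O[C@@H]1C=CC(=O)[C@@H](CO)O1` gives 9700 nM. That is level with compound 1 `CCCO[C@@H]1C=CC(=O)[C@@H](CO)O1` at 10700 nM, and weaker than compound 2 `CCO[C@@H]1C=CC(=O)[C@@H](CO)O1` at 3500 nM.

Compound 4 `C=CCO[C@@H]1C=CC(=O)[C@@H](CO)O1` has allyl in place of isopropyl on an oxygen on a saturated carbon.

Going by the values given here, the closest precedent is the swap of propyl for isopropyl, a 1.1-fold lower number from compound 1 to compound 3 (0.04 log units; within the scatter). Larger steps appear only around compound 2: a 3.1-fold lower number from compound 1 to compound 2 (0.49 log units; beyond the scatter) and a 2.8-fold higher number from compound 2 to compound 3 (0.44 log units; beyond the scatter). Neither of those replaces one group with another of equal size, so a small step in this assay seems likeliest, with no firm direction. The expected change is a 1.2-fold lower number from compound 3 to compound 4 (0.08 log units; within the scatter). Compound 4 is estimated at 8000 nM, with an expected range of 3500 nM to 16000 nM.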

Compound 4, half-maximal inhibitory concentration: 4900 nM
The estimate for compound 4 lay 1.6-fold (0.21 log units) above the measured number, within the range that was stated.
By their numbers in this assay, from the lowest: compounds 2, 4, 3 and 1 (each within the scatter of the next, the first and the last beyond it).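

In this assay there is a 2.0-fold lower number from compound 3 to compound 4 (0.30 log units; within the scatter) and a 1.4-fold higher number from compound 2 to compound 4 (0.15 log units; within the scatter), both inside the scatter, so allyl on this oxygen cannot be told apart from isopropyl or from the group in compound 2. Only a 2.2-fold lower number from compound 1 to compound 4 (0.34 log units; beyond the scatter) passes beyond the scatter, and modestly, so allyl stands apart from propyl alone. Nothing shown gives a reason for that gap. Still open, as far as these compounds go, is how a propargyl, cyclopropylmethyl or benzyl group on this oxygen would compare with allyl, and whether a longer chain such as butyl would follow propyl.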